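Cinnamoyl hydrazides: swapping a nitro for a methyl

A few compounds are considered here, and "the series" means these few. Any claim that something is new, unique, unknown or untested is made for them only; others in the source may bear on it.

Of the compounds shown here, three sharing one core have been tested in an ADME assay on cells (Macrophage) for cytotoxicity, read by MTT assay, with a stated time of 24 h; a higher number here means that more compound is tolerated, a lower number that less compound is tolerated. Compound 1 `O=C(/C=C/c1cccc(Br)c1)NNC(=O)c1ccc2c(c1)OCCO2` gives 351000 nM. Compound 2 `O=C(/C=C/c1ccc(F)cc1)NNC(=O)c1ccc2c(c1)OCCO2` gives 319000 nM. Compound 3 `O=C(/C=C/c1ccccc1[N+](=O)[O-])NNC(=O)c1ccc2c(c1)OCCO2` gives 257000 nM, the lowest of the three numbers, though the steps of a 1.4-fold lower number from compound 1 to compound 3 (0.14 log units; within the scatter) and a 1.2-fold lower number from compound 2 to compound 3 (0.09 log units; within the scatter) are both within the scatter, as is a 1.1-fold lower number from compound 1 to compound 2 (0.04 log units; within the scatter). So far, changing the substituent on the phenyl ring at the end of the double-bonded chain has left this assay essentially unmoved.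

Compound 4 `Cc1ccccc1/C=C/C(=O)NNC(=O)c1ccc2c(c1)OCCO2` differs from compound 3 in one place: methyl in place of nitro on an aromatic carbon. Among the measured compounds shown here, no measured step covers a nitro-to-methyl exchange directly; the steps that bear on it are the three ring-substituent swaps above, each within the scatter. On that basis compound 4 is expected to show no step beyond the scatter, with a 1.2-fold higher number from compound 3 to compound 4 (0.07 log units; within the scatter) as the estimated change. Compound 4 is therefore estimated at 300000 nM, with a range from 150000 nM to 600000 nM.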

Compound 4, half-maximal cytotoxic concentration: 268000 nM
For compound 4 the middle estimate is 1.1-fold (0.05 log units) above the measured one; the measured number falls inside the stated range.
By their numbers in this assay, from the lowest: compounds 3, 4, 2 and 1 (each within the scatter of the next).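

Among the compounds shown here, compound 3 and compound 4 are the first pair here to carry different groups at the same place on the phenyl ring, an aromatic carbon ortho to a large group, so this step isolates the group itself from any shift in its position. Replacing nitro, with its two hydrogen-bond acceptors, by methyl, with none, leaves this assay within the scatter (a 1.0-fold higher number from compound 3 to compound 4 (0.02 log units; within the scatter)), and compound 4 also stays within the scatter of the compounds substituted elsewhere on the ring (a 1.2-fold lower number from compound 2 to compound 4 (0.08 log units; within the scatter)) and (a 1.3-fold lower number from compound 1 to compound 4 (0.12 log units; within the scatter)). No measurement on hand explains why this assay stays so flat.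

On these data alone, whether an amine or a carboxylic acid at this same place would move the number remains open. So does the effect of changing the shared core, which is identical in all four compounds.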